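From cyclopropyl to isobutyl on a sulfonamide nitrogen

The source may report more compounds than this note shows. Statements on the series, on what has been measured and on what is new or still open speak of the compounds shown alone.

For the measured compounds named here, in a functional assay on MV4-11 cells (Homo sapiens) for inhibition, with a stated time of 72 h (a higher number here means a weaker inhibitor, a lower number a stronger inhibitor), compound 1 (`O=C(NO)c1ccc(CN(C2CC2)S(=O)(=O)c2cc(F)c(F)c(F)c2F)cc1`) gives 400 nM and is the stronger inhibitor of the two compounds measured so far. Compound 2 (`CC(C)N(Cc1ccc(C(=O)NO)cc1)Cc1cc(F)c(F)c(F)c1F`) gives 7430 nM in the same test, a gap well beyond the usual scatter. These two compounds differ in more than one place, so no single change can be read from them. Compound 3 (`CC(C)CN(Cc1ccc(C(=O)NO)cc1)S(=O)(=O)c1cc(F)c(F)c(F)c1F`) has not yet been measured. It keeps the core of compound 1 but carries isobutyl in place of cyclopropyl on a sulfonamide nitrogen. Going by the values given here, no measured pair shows this kind of change, so the expectation rests on the structural change alone. A small move toward weaker inhibition is expected, an estimated step (a 1.3-fold higher number from compound 1 to compound 3 (0.10 log units; within the scatter)) that may stay within the scatter. In this assay compound 3 is estimated at 500 nM with an expected range of 150 nM to 1700 nM for the coming measurement.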

Compound 3, half-maximal inhibitory concentration: 520 nM
Compound 3: middle estimate off by 1.0-fold (0.02 log units), on the low side, and the stated range covers the measured number.
By their numbers in this assay, from the lowest: compounds 1 and 3 (each within the scatter of the next); then compound 2.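

For the compounds shown here, this is the first comparison in the set that differs in one place: on a sulfonamide nitrogen, isobutyl in place of cyclopropyl gives a 1.3-fold higher number from compound 1 to compound 3 (0.11 log units; within the scatter) in this assay. At this position, then, the three-membered carbon ring and the open isobutyl chain cannot be told apart in this test, and the ring is not needed to keep the number in the range of compound 1. No supporting data bear on why the two groups read alike.

On these data alone, whether a longer chain, an amine or a carboxylic acid on this nitrogen would also stay within that range remains open. Compound 2 differs from compound 1 in more than one place, so the part played by the sulfonyl group in its much higher number also remains unresolved.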